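The source may report more compounds than this note shows. Statements on the series, on what has been measured and on what is new or still open speak of the compounds shown alone.

Two compounds share a core in which an amide links a trifluoromethyl-bearing hydroxy acid to an aromatic ring. Compound 1 `Cn1nnnc1-c1ccc(NC(=O)C(C)(O)C(F)(F)F)cc1` carries a methyltetrazolyl group on that ring, and in an assay on a protein complex (Cavia porcellus) with sulfonylurea receptors; K-ATP channels (Homo sapiens) as the target (a lower number here means a stronger inhibitor, a higher number a weaker inhibitor), compound 1 gives 30900 nM. Compound 2 `CCCN(CCC)S(=O)(=O)c1ccc(NC(=O)C(C)(O)C(F)(F)F)cc1` instead carries a sulfonyl group bearing a dipropylamino substituent; in this assay compound 2 gives 6440 nM, the lowest number of the two, and the gap to compound 1 lies beyond the scatter of the measurement. Compound 3 `CC(O)(C(=O)Nc1ccc(S(=O)(=O)N2CCCC2)cc1)C(F)(F)F` is not yet measured. It differs from compound 2 in one place: pyrrolidin-1-yl in place of dipropylamino on a sulfonyl sulfur. Among the measured compounds shown here, with no measured pair showing what such a change does here, only a modest step is expected, with a slight lean toward a higher number, so that the expected change from compound 2 to compound 3 in this assay is a 1.6-fold higher number from compound 2 to compound 3 (0.19 log units; within the scatter). For compound 3 the expected result in this assay is 10000 nM, within a range from 3000 nM to 35000 nM.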

Compound 3, half-maximal inhibitory concentration: 880 nM
For compound 3 the middle estimate is 11-fold (1.06 log units) above the measured one; the measured number lies below the stated range.
By their numbers in this assay, from the lowest: compound 3; then compound 2; then compound 1.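

In this assay the choice of group on the sulfonyl sulfur clearly matters: pyrrolidin-1-yl in place of dipropylamino gives a 7.3-fold lower number from compound 2 to compound 3 (0.86 log units; beyond the scatter) and shows that the number depends on the amine part of this group, not merely on a sulfonyl being present. Changing the whole group on the aromatic carbon, with (pyrrolidin-1-yl)sulfonyl in place of 1-methyl-1H-tetrazol-5-yl, gives a 35-fold lower number from compound 1 to compound 3 (1.55 log units; beyond the scatter) and spans the widest gap among these compounds. Nothing available explains why the ring gives a lower number than the open chains. Going by these compounds, whether piperidine, morpholine or a shorter chain such as dimethylamino on the sulfonyl sulfur would lower the number further remains open. On these data alone, the shared core is the same throughout, so the effect of changing it, for instance methyl in place of trifluoromethyl, also remains unknown.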